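Methyl to fluoro on a shared core

This account rests on a few compounds, and the source may have more. Where it says the series, first, only, none or still open, it means among the compounds named here.

compound 1 `C#CCn1c(=O)c(/C=C/C(=O)/C=C(O)/C=C/c2ccc(O)c(OC)c2)cc2ccccc21` gives 25400 nM
compound 2 `C#CCn1c(=O)c(/C=C/C(=O)/C=C(O)/C=C/c2ccc(O)c(OC)c2)cc2cc(OC)ccc21` gives 38100 nM
compound 3 `C#CCn1c(=O)c(/C=C/C(=O)/C=C(O)/C=C/c2ccc(O)c(OC)c2)cc2cc(C)ccc21` gives 21800 nM

These values come from a functional assay on NCI-H460 cells (Homo sapiens) for cytotoxicity, read by MTT assay, with a stated time of 24 h (a higher number here means a weaker inhibitor, a lower number a stronger inhibitor), and the three compounds differ only at a single aromatic carbon, which bears hydrogen, methoxy or methyl. Compound 3, with methyl, gives 21800 nM and sits level with the other two. Three measured steps show how small the swaps at this carbon have been so far: a 1.5-fold higher number from compound 1 to compound 2 (0.18 log units; within the scatter), a 1.2-fold lower number from compound 1 to compound 3 (0.07 log units; within the scatter) and a 1.7-fold lower number from compound 2 to compound 3 (0.24 log units; within the scatter), all of them modest.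

Compound 4 `C#CCn1c(=O)c(/C=C/C(=O)/C=C(O)/C=C/c2ccc(O)c(OC)c2)cc2cc(F)ccc21` has not yet been measured. It carries fluoro in place of methyl on an aromatic carbon, and this is the same carbon that varies in the other three. Among the measured compounds shown here, no measured compound carries fluoro, so the data offer no direct guide to this group. With all three steps inside the scatter, the expectation in this assay is no step beyond the scatter, and no direction is favoured. Compound 4 is expected at 24000 nM, with an estimated range from 12000 nM to 48000 nM as the likely span. This estimate amounts to a 1.1-fold higher number from compound 3 to compound 4 (0.04 log units; within the scatter), a step expected to be too small to tell apart from repeat measurements.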

Compound 4, half-maximal inhibitory concentration: 44300 nM
The estimate for compound 4 lay 1.8-fold (0.27 log units) below the measured number; the measured number falls inside the stated range.
By their numbers in this assay, from the lowest: compounds 3, 1, 2 and 4 (each within the scatter of the next, the first and the last beyond it).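

In this assay this carbon now yields its first step beyond the scatter: fluoro in place of methyl gives a 2.0-fold higher number from compound 3 to compound 4 (0.31 log units; beyond the scatter) and so a weaker inhibitor, although the step is modest and only just clears the usual variation between repeats. That gap holds only against methyl, since fluoro stays within the scatter of the other two groups, with a 1.2-fold higher number from compound 2 to compound 4 (0.07 log units; within the scatter) and a 1.7-fold higher number from compound 1 to compound 4 (0.24 log units; within the scatter) as the steps, and methyl itself could not be told apart from hydrogen or methoxy. The data give no reason why swapping one single atom for another at this carbon produces this gap.

Going by these compounds, whether this carbon can move the number much further stays open, as a chloro group, an amine, a carboxylic acid or a longer chain might behave quite differently from the four small groups compared here. Also open, on these data alone, is whether changes elsewhere on the shared core, such as at the propargyl-bearing nitrogen or on the far aromatic ring, would matter more than any swap at this one carbon.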